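Compound 3 to compound 4: bromo replaces methyl

The compounds below may be only part of what the source reports. "The series", "measured", "known", "first", "only" and "open" are said of these compounds alone.

Within the data shown here, compound 3 `Cc1ccc(Nc2cc(-c3ccccc3)oc(=O)c2)cc1` gives 0.059 uM in a functional assay on KBVIN cells (Homo sapiens) for cytotoxicity, read by MTT assay, with a stated time of 72 h (a higher number here means that more compound is needed for the effect, a lower number that less compound is needed), the lowest of the three numbers measured so far. Its nearest neighbour is compound 2 `O=c1cc(Nc2ccccc2)cc(-c2ccccc2)o1`, which gives 0.15 uM; compound 1 `O=c1cc(NC2CCCCC2)cc(/C=C/c2ccccc2)o1` lies furthest away with 1.24 uM. Among the measured compounds shown here, the one single-point step inside the set runs a 2.5-fold lower number from compound 2 to compound 3 (0.41 log units; beyond the scatter), so putting a methyl on the six-membered ring moved the number down beyond the scatter.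

Compound 4 `O=c1cc(Nc2ccc(Br)cc2)cc(-c2ccccc2)o1` is the next member. It differs from compound 3 by bromo in place of methyl on an aromatic carbon. For the measured compounds named here, no measured step exchanges one substituent for another at this place; the step from compound 2 to compound 3 shows only that a methyl there beats hydrogen. Going by the values given here, a bromo there has no precedent in the set, so the most that can be said is that the substituted ring of compound 3 already sits at the low end, and another group of one heavy atom at the same place, para to a large group, is expected to leave the number close to where it stands, with the direction open. The step from compound 3 to compound 4 is expected to be a 1.0-fold higher number from compound 3 to compound 4 (0.01 log units; within the scatter), within the scatter. For compound 4 the estimate in this assay is 0.06 uM, with a range from 0.025 uM to 0.15 uM.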

Compound 4, concentration for half-maximal effect: 0.24 uM
The estimate for compound 4 lay 4.0-fold (0.60 log units) below the measured number; the whole stated range lies below it.
By their numbers in this assay, from the lowest: compound 3; then compounds 2 and 4 (each within the scatter of the next); then compound 1.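

In this assay, this place para to a large group does not treat two single heavy atoms alike: the exchange of one substituent for another gives a 4.1-fold higher number from compound 3 to compound 4 (0.61 log units; beyond the scatter) and so the 4-methylphenyl to 4-bromophenyl change is not neutral. Bromo in place of hydrogen gives a 1.6-fold higher number from compound 2 to compound 4 (0.20 log units; within the scatter) and so the bromo compound does not separate from the unsubstituted compound, whereas methyl in place of hydrogen gave a 2.5-fold lower number from compound 2 to compound 3 (0.41 log units; beyond the scatter) and thus compound 3 stands apart from both of its neighbours at this place. No measured data on the compounds bear on the reason for this difference between methyl and bromo.

As far as these compounds go, with only hydrogen, methyl and bromo compared at this place, it remains open whether the lower number of compound 3 is particular to methyl or would be shared by groups such as ethyl, methoxy, chloro or an amine. From the compounds shown here alone, it also remains open whether the same order of methyl and bromo would hold at other places on this ring or on the core of compound 1, which carries a cyclohexyl group on its nitrogen.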